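Sulfonamide aryl swap: working notes toward compound 4

The compounds below may be only part of what the source reports. "The series", "measured", "known", "first", "only" and "open" are said of these compounds alone.

In a functional assay on M21 cells (Homo sapiens) for antiproliferative activity, read by sulforhodamine B assay, with a stated time of 48 h (a lower number here means a stronger inhibitor, a higher number a weaker inhibitor), compound 3 `Cc1cccc(NS(=O)(=O)c2ccc(N3CCNC3=O)cc2)c1C` gives 110 nM, the highest of the two numbers in hand; nearest is compound 1 `O=C1NCCN1c1ccc(S(=O)(=O)Nc2cccc(Br)c2)cc1`, which in this assay gives 59 nM. In this assay compound 2 `CC(C)Cc1ccc(NS(=O)(=O)c2ccc(N3CCNC3=O)cc2)cc1` gives > 1000 nM, which is a limit of the assay rather than a number (the limit of > 1000 nM in this assay, at which 1 of the 3 values shown sits). Compound 4 `O=C1NCCN1c1ccc(S(=O)(=O)Nc2ccc(F)cc2)cc1` differs from compound 3 by 4-fluorophenyl in place of 2,3-dimethylphenyl on a sulfonamide nitrogen. Going by the values given here, the one measured step at the same position, a 1.9-fold higher number from compound 1 to compound 3 (0.27 log units; within the scatter), stays within the scatter, so exchanging one aryl group for another on the sulfonamide nitrogen has moved the number little so far, while compound 2 shows that a limit can also result there. For compound 4 a step of a 1.4-fold higher number from compound 3 to compound 4 (0.13 log units; within the scatter) is expected, with the number estimated at 150 nM, between 50 nM and 600 nM.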

Compound 4, half-maximal inhibitory concentration: 230 nM
Compound 4: the middle estimate sits 1.5-fold (0.19 log units) below what was measured; measured number inside the range.
By their numbers in this assay, from the lowest: compounds 1 and 3 (each within the scatter of the next); then compound 4. At a limit, above all of these: compound 2.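

In this assay, an aryl exchange on the sulfonamide nitrogen now moves the number beyond the scatter: a 2.1-fold higher number from compound 3 to compound 4 (0.32 log units; beyond the scatter), and a 3.9-fold higher number from compound 1 to compound 4 (0.59 log units; beyond the scatter). Compound 2 stands at a limit of the assay, not a number: the limit of > 1000 nM in this assay, at which 1 of the 4 values shown sits. The step involving that limit, an at least 4.3-fold lower number from compound 2 to compound 4 (0.63 log units; beyond the scatter), therefore reads only as a bound, with fluoro in place of isobutyl.

From the compounds shown here alone, whether the 4-fluorophenyl result follows from the fluoro group itself or from where it sits stays open. Also open, going by these compounds, is how an amine or a carboxylic acid on that aryl group would read.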